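The source may report more compounds than this note shows. Statements on the series, on what has been measured and on what is new or still open speak of the compounds shown alone.

Measured in a functional assay on CNE2Z cells (Homo sapiens) for inhibition, read by MTT assay, with a stated time of 72 h; on this read-out higher numbers stand for weaker inhibition and lower numbers for stronger inhibition:
- compound 1 `C=CCc1ccc(OCc2c(Cl)cccc2Cl)c(-c2ccc(OCc3c(Cl)cccc3Cl)c(CC=C)c2)c1`: > 50000 nM (a limit)
- compound 2 `C=CCc1ccc(O)c(-c2ccc(OCc3ccccc3)c(CC=C)c2)c1`: 30300 nM
- compound 3 `C=CCc1ccc(O)c(-c2ccc(OCc3ccc(Cl)c(Cl)c3)c(CC=C)c2)c1`: 17800 nM

Among the compounds with values here, compound 3 lies within the scatter of compound 2, which holds the only other number.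

Next is compound 4 `C=CCc1ccc(O)c(-c2ccc(OCc3c(Cl)cccc3Cl)c(CC=C)c2)c1`, with 2,6-dichlorophenyl in place of 3,4-dichlorophenyl on a saturated chain carbon bound to an oxygen on an aromatic ring. Within the data shown here, the one measured step at this place is a 1.7-fold lower number from compound 2 to compound 3 (0.23 log units; within the scatter). No exchange between dichlorophenyl groups has been measured. No step beyond the scatter is therefore expected in this assay, in either direction. The estimate for compound 4 is an expected 20000 nM, with an expected range of 9000 nM to 45000 nM. This corresponds to an expected 1.1-fold higher number from compound 3 to compound 4 (0.05 log units; within the scatter).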

Compound 4, half-maximal inhibitory concentration: 16400 nM
Compound 4: middle estimate off by 1.2-fold (0.09 log units), on the high side, and the stated range covers the measured number.
By their numbers in this assay, from the lowest: compounds 4, 3 and 2 (each within the scatter of the next). At a limit, above all of these: compound 1.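

In this assay, the placement of the two chlorines on the benzyl group makes no readable difference, a 1.1-fold lower number from compound 3 to compound 4 (0.04 log units; within the scatter), and 2,6-dichlorophenyl also stays within the scatter of phenyl, a 1.8-fold lower number from compound 2 to compound 4 (0.27 log units; within the scatter). Hydrogen in place of 2,6-dichlorobenzyl on an oxygen on an aromatic ring gives the only step beyond the scatter here, an at least 3.0-fold lower number from compound 1 to compound 4 (0.48 log units; beyond the scatter). Compound 1 is read as a limit, not a number: the limit of > 50000 nM in this assay, at which 1 of the 4 values shown sits.

Open, on these data alone, is whether an amine or a carboxylic acid on the benzyl ring would shift the number beyond the scatter. Also open, as far as these compounds go, is how a longer chain between the oxygen and the ring would read.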